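Swapping methyl for chloro on an inactive compound

The compounds below may be only part of what the source reports. "The series", "measured", "known", "first", "only" and "open" are said of these compounds alone.

- compound 1 `Cc1cc(-c2c(-c3cccc(C)n3)nn3c2C(C)C(C)(C)C3)ccn1`: > 100000 nM (a limit)
- compound 2 `CC1(C)Cc2c(-c3ccncc3)c(-c3ccccc3C#N)nn2C1`: > 100000 nM (a limit)
- compound 3 `CCc1cccc(-c2nn3c(c2-c2ccncc2)C(C)C(C)(C)C3)n1`: > 100000 nM (a limit)

All three compounds were tested in a functional assay on MCF7 cells (Homo sapiens) for cytotoxicity, with a stated time of 72 h; a lower number here means a stronger inhibitor, a higher number a weaker inhibitor. None of them gave an actual number, and the picture so far is a single one: the limit of > 100000 nM in this assay, at which 3 of the 3 values shown sit. Compound 1 therefore stands at > 100000 nM, which is a limit of the assay and not a measured potency.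

The next compound to be tested is compound 4 `Cc1cccc(-c2nn3c(c2-c2ccnc(Cl)c2)C(C)C(C)(C)C3)n1`. It differs from compound 1 in one place: chloro in place of methyl on an aromatic carbon. In words, this is chloro in place of methyl on an aromatic carbon, so that 2-methylpyridin-4-yl becomes 2-chloropyridin-4-yl.

Going by the values given here, no two measured compounds differ in just one place, so the data give no direct guide to the size of this step. All three measured compounds sit at the same limit, and none goes against that pattern. The expectation for this assay is therefore no clear gain in potency, because of the limit of > 100000 nM in this assay, at which 3 of the 3 values shown sit.

The estimated a number no higher from compound 1 to compound 4 (the limit leaves the size open) is expected to stay within the usual scatter. For compound 4 the expected value is 100000 nM, with an estimated range of 40000 nM to 200000 nM.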

Compound 4, half-maximal inhibitory concentration: > 100000 nM
Compound 4: a limit, no number (the forecaster's own chance of this, stated with the estimate: 85%); the middle value sits exactly at the limit.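

Compound 4 gives > 100000 nM in this assay, which is a limit and not a number. Compound 1 also stands at a limit, so no step can be read for the swap of methyl for chloro between compound 1 and compound 4. The compounds shown leave open whether that swap changes potency in this assay at all.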